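A few compounds are considered here, and "the series" means these few. Any claim that something is new, unique, unknown or untested is made for them only; others in the source may bear on it.

Of the compounds shown here, three built on one shared core have been tested in a functional assay on SK-MEL-28 cells (Homo sapiens) for inhibition; on this read-out lower numbers stand for stronger inhibition and higher numbers for weaker inhibition: compound 1 `CC(=O)Oc1ccc(/C=C/c2ccc3ccccc3c2)cc1`, compound 2 `FC(F)(F)Oc1ccc(/C=C/c2ccc3ccccc3c2)cc1` and compound 3 `Cc1ccc(/C=C/c2ccc3ccccc3c2)cc1`. In this assay compound 1 gives > 5000 nM, which is a limit of the assay and not a number. Compound 2 gives > 5000 nM, again a limit. Compound 3 gives > 5000 nM, also a limit, so compound 3 has no exact place on the scale.

The next compound is compound 4 `Cc1ccc(/C=C\c2ccc3ccccc3c2)cc1`. The change is the two compounds have the same atoms and bonds and differ only in configuration as drawn: 1 of 1 stereo elements differ; a double bond is drawn E in compound 3 and Z in compound 4: a double bond is drawn E in compound 3 and Z in compound 4.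

Three measured steps form the background: a step that the two limits leave unreadable from compound 1 to compound 2, a step that the two limits leave unreadable from compound 1 to compound 3 and a step that the two limits leave unreadable from compound 2 to compound 3. None of them has a readable size, and none alters the double bond, so they offer no direct guide to this change. What they do show is a flat picture: the limit of > 5000 nM in this assay, at which 3 of the 3 values shown sit.

The expectation therefore starts from that limit, with only a small step, if any, and with little confidence in its direction. The expected step is an at least 1.2-fold lower number from compound 3 to compound 4 (0.09 log units; that floor lies within the scatter). It remains quite possible that the assay will again report only a limit. For compound 4 the estimated value is 4000 nM, with an expected range from 800 nM to 10000 nM.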

Compound 4, half-maximal inhibitory concentration: > 5000 nM
Compound 4: only a limit was reported; the forecaster's own chance of this, stated with the estimate: 60%; middle value at least 1.2-fold (0.09 log units) from the limit.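

In this assay compound 4 gives > 5000 nM, which is a limit of the assay and not a number. Compound 3 also sits at a limit, so no step between compound 3 and compound 4 can be read, and the picture stays flat: the limit of > 5000 nM in this assay, at which 4 of the 4 values shown sit.

The compounds shown leave open whether either double-bond form has any measurable effect in this assay.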